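From 2-fluorobenzyl to 4-hydroxybenzyl

This account rests on a few compounds, and the source may have more. Where it says the series, first, only, none or still open, it means among the compounds named here.

Compound 1 `COc1cccc(CNCc2c(C(=O)O)n(Cc3ccc(O)cc3)c3cc(C(C)C)ccc23)c1`: 7080 nM
Compound 2 `COc1ccc(Cn2c(C(=O)O)c(CNCc3cccc(OC)c3)c3ccccc32)cc1`: 52900 nM
Compound 3 `COc1cccc(CNCc2c(C(=O)O)n(Cc3ccccc3F)c3ccccc23)c1`: > 50000 nM, a limit

In a functional assay on Bel-7402 cells (Homo sapiens) for antiproliferative activity, read by MTT assay, with a stated time of 72 h (on this read-out higher numbers stand for weaker inhibition and lower numbers for stronger inhibition), compound 3 gives only a limit, > 50000 nM, and not a number. Compound 4 `COc1cccc(CNCc2c(C(=O)O)n(Cc3ccc(O)cc3)c3ccccc23)c1` has 4-hydroxyphenyl in place of 2-fluorophenyl on a saturated chain carbon bound to an aromatic nitrogen. Among the compounds with values here, the one measured step at this place is a step that the limit leaves unreadable from compound 2 to compound 3, so it offers no size to carry over. Two values guide the expectation instead. Compound 1, which also carries 4-hydroxyphenyl but on a core of its own, gives 7080 nM. On the core of compound 4, compound 2 gives 52900 nM. The expected change is a modest one towards stronger inhibition, an at least 2.0-fold lower number from compound 3 to compound 4 (0.30 log units; that floor lies within the scatter). Compound 4 is estimated at 25000 nM, with an expected range of 8000 nM to 70000 nM.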

Compound 4, half-maximal inhibitory concentration: > 50000 nM
Compound 4 was reported as a limit; the forecaster's own chance of this, stated with the estimate: 30%; middle value at least 2.0-fold (0.30 log units) away from the limit.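

Within the data shown here, the one readable step concerns not the benzyl group but hydrogen in place of isopropyl on an aromatic carbon: an at least 7.0-fold higher number from compound 1 to compound 4 (0.84 log units; beyond the scatter). So 4-hydroxyphenyl on a saturated chain carbon bound to an aromatic nitrogen does not alone give the value of compound 1; the isopropyl group is present there too. The steps from compound 2 and from compound 3 to compound 4 cannot be read, and the shared core meets a limit: the limit of > 50000 nM in this assay, at which 2 of the 4 values shown sit.

From the compounds shown here alone, whether 2-fluorophenyl and 4-hydroxyphenyl differ on that core stays open. Also open, going by these compounds, is how a 4-aminophenyl group at this place, or a tert-butyl group in place of isopropyl, would read.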